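Halogen swap on a triazole, tested twice

The source may hold more compounds than are shown below. What is called first, only, known or untested is meant among the compounds shown, and "the series" means these compounds.

Compound 1 `ClCc1cn(Cc2ccccc2)nn1` and compound 2 `BrCc1cn(Cc2ccccc2)nn1` share a core and differ in one place: bromo in place of chloro on a saturated chain carbon bound to an aromatic carbon. In a functional assay on HeLa cells (Homo sapiens), read by colorimetric assay, with a stated time of 72 h (a higher number here means that more compound is needed for the effect, a lower number that less compound is needed), compound 1 gives 18 ug/mL, while compound 2 gives 2 ug/mL, so the step is a 9.0-fold lower number from compound 1 to compound 2 (0.95 log units; beyond the scatter). Compound 3 `CC(=O)OC[C@H]1O[C@@H](n2nncc2CCl)[C@H](OC(C)=O)[C@@H](OC(C)=O)[C@@H]1OC(C)=O` carries the same chloromethyl-bearing triazole on a different core; the difference between the two cores is not broken down here. In this assay compound 3 gives 25 ug/mL. Compound 4 `CC(=O)OC[C@H]1O[C@@H](n2nncc2CBr)[C@H](OC(C)=O)[C@@H](OC(C)=O)[C@@H]1OC(C)=O` is not yet measured and differs from compound 3 by the same change: bromo in place of chloro on a saturated chain carbon bound to an aromatic carbon. Within the data shown here, because the one earlier instance, a 9.0-fold lower number from compound 1 to compound 2 (0.95 log units; beyond the scatter), was well beyond the scatter, a step of similar direction is expected here, a 7.1-fold lower number from compound 3 to compound 4 (0.85 log units; beyond the scatter), though resting on a single precedent. Compound 4 is therefore estimated at 3.5 ug/mL, within 1.2 ug/mL to 10 ug/mL.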

Compound 4, concentration for half-maximal effect: 4 ug/mL
For compound 4 the middle estimate is 1.1-fold (0.06 log units) below the measured one; low and high end bracket the measured number.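

Putting bromo in place of chloro gives a 6.3-fold lower number from compound 3 to compound 4 (0.80 log units; beyond the scatter) in this assay. The step carries over from one core to the other, with the same direction and a matching size: the same change on two cores in this assay, a 9.0-fold lower number (0.95 log units; beyond the scatter) from compound 1 to compound 2 and a 6.3-fold lower number (0.80 log units; beyond the scatter) from compound 3 to compound 4, 1.4-fold (0.16 log units) apart, within the scatter of two such steps. Among these compounds, this rests on only two pairs of compounds in a single cell assay, so it shows that the change transfers between these two cores, but not that it would do so on any other core, and it does not explain the effect.

The compounds shown leave open how iodo, an amine or a hydroxyl would compare with chloro and bromo on that saturated chain carbon. They also leave open whether a longer chain carrying the bromo would keep the step.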